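Dimethylphenyl Swap on a Weak Triazole Amide

A few compounds are considered here, and "the series" means these few. Any claim that something is new, unique, unknown or untested is made for them only; others in the source may bear on it.

Compound 1 `CC(C)n1ncc2c(C(=O)Nc3ccccc3)cccc21`: in a functional assay on MGC-803 cells (Homo sapiens) for inhibition, read by MTT assay, with a stated time of 72 h (on this read-out higher numbers stand for weaker inhibition and lower numbers for stronger inhibition), compound 1 gives 38500 nM.
Compound 2 `CC(C)n1ncc2c(C(=O)NCc3cn(-c4ccccc4)nn3)cccc21`: in this assay compound 2 gives > 40000 nM, which is a limit of the assay rather than a number.

Compound 2 thus stands at the edge of what this assay reports (the limit of > 40000 nM in this assay, at which 1 of the 2 values shown sits). Compound 3 `Cc1ccc(-n2cc(CNC(=O)c3cccc4c3cnn4C(C)C)nn2)cc1C` differs from compound 2 by 3,4-dimethylphenyl in place of phenyl on an aromatic nitrogen. No step between two measured compounds is shown, so the change can only be judged loosely. The expected step is a number no higher from compound 2 to compound 3 (the limit leaves the size open), none beyond the scatter. Compound 3 is estimated at 40000 nM, between 15000 nM and 100000 nM, and may again appear as a limit.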

Compound 3, half-maximal inhibitory concentration: > 40000 nM
Compound 3 ended at the assay's limit; the forecaster's own chance of this, stated with the estimate: 60%; the middle value sits exactly at the limit.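

Compound 2 and compound 3 both end at a limit of this assay, not at a number, and no step can be read between them. The compounds shown leave open whether 3,4-dimethylphenyl in place of phenyl changes inhibition at all.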